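The compounds below may be only part of what the source reports. "The series", "measured", "known", "first", "only" and "open" are said of these compounds alone.

Three compounds of one shared core have been measured in a functional assay on HeLa cells (Homo sapiens) for inhibition, read by sulforhodamine B assay, with a stated time of 48 h; a higher number here means a weaker inhibitor of growth, a lower number a stronger inhibitor of growth:

Compound 1 `COC(=O)[C@@]1(C)CCC=C2[C@@H]1CC[C@@H](C)[C@]2(C)Cc1c[nH]c2ccc(Br)cc12` gives 10000 nM.
Compound 2 `COC(=O)[C@@]1(C)CCC=C2[C@@H]1CC[C@@H](C)[C@]2(C)Cc1c[nH]c2c(Br)cccc12` gives 13000 nM.
Compound 3 `COC(=O)[C@@]1(C)CCC=C2[C@@H]1CC[C@@H](C)[C@]2(C)Cc1c(C)[nH]c2ccc(Br)cc12` gives 11000 nM.

Compound 3 stands second highest of these three numbers, but all three lie close together. Its nearest neighbour is compound 1: the step of a 1.1-fold higher number from compound 1 to compound 3 (0.04 log units; within the scatter) is within the scatter. Compound 2 lies a little further off, yet its value and that of compound 3 are also within the usual scatter of each other, so no order among the three can be claimed.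

Compound 4 `COC(=O)[C@@]1(C)CCC=C2[C@@H]1CC[C@@H](C)[C@]2(C)Cc1c(C)[nH]c2ccc(C(F)(F)F)cc12` differs from compound 3 in one place: trifluoromethyl in place of bromo on an aromatic carbon. Within the data shown here, no measured step swaps the bromo for another group; the only step in hand, a 1.1-fold higher number from compound 1 to compound 3 (0.04 log units; within the scatter), concerns a methyl elsewhere and does not bear on this change. With nothing pointing either way, the expected step of a 1.1-fold higher number from compound 3 to compound 4 (0.04 log units; within the scatter) is none beyond the scatter. Compound 4 is therefore estimated at 12000 nM in this assay , with a range from 5000 nM to 30000 nM.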

Compound 4, concentration for 50% growth inhibition: 12000 nM
Beside the measured number, compound 4's estimate shows no gap at the digits printed; the range from low to high includes it.
By their numbers in this assay, from the lowest: compounds 1, 3, 4 and 2 (each within the scatter of the next).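

In this assay, putting trifluoromethyl in place of bromo on this aromatic carbon gives a 1.1-fold higher number from compound 3 to compound 4 (0.04 log units; within the scatter). Among these compounds, this is the first measured step that replaces the group at this position, and it shows that a group of 4 heavy atoms can stand where bromo's single heavy atom stood without a difference that can be told from the scatter. No separate measurement bears on this result.

The compounds shown leave open whether an amine or a carboxylic acid on this aromatic carbon would also stay within the scatter of compound 3 or would lie clearly apart from it. They also leave open whether trifluoromethyl in place of bromo would read the same on compound 1, which lacks the methyl carried by compound 3.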